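Chloro for fluoro on the difluorophenyl sulfonyl ring

A few compounds are considered here, and "the series" means these few. Any claim that something is new, unique, unknown or untested is made for them only; others in the source may bear on it.

Working notes on the series. Going by the values given here, compound 1 `O=S(=O)(c1ccc(F)c(F)c1)c1cnc2c(F)cccc2c1-c1cccc(F)c1` has been measured in an ADME assay on microsomes from liver (Homo sapiens) for metabolic stability, tested at 2.5 uM (on this read-out higher numbers stand for fast clearance and lower numbers for slow clearance), and gives 1.28 mL/min; this is the higher of the two numbers so far, with compound 2 closest. Compound 2 `O=S(=O)(c1ccc(F)c(F)c1)c1cnc2c(F)cccc2c1-c1cccc(Cl)c1` gives 1.13 mL/min in this assay. Among the compounds with values here, the one measured step, a 1.1-fold lower number from compound 1 to compound 2 (0.05 log units; within the scatter), swaps chloro for fluoro on the pendant phenyl and stays within the scatter.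

Compound 3 `O=S(=O)(c1ccc(F)c(Cl)c1)c1cnc2c(F)cccc2c1-c1cccc(F)c1` is not yet measured. It differs from compound 1 by chloro in place of fluoro on an aromatic carbon, that is, 3,4-difluorophenyl becoming 3-chloro-4-fluorophenyl on the sulfonyl side; the place is an aromatic carbon of a six-membered aromatic ring of carbon only, ortho to a fluoro group and meta to a large group. Within the data shown here, the only step that bears on it is the same exchange at a different ring, a 1.1-fold lower number from compound 1 to compound 2 (0.05 log units; within the scatter), which was within the scatter. No step beyond the scatter is therefore expected in this assay in either direction, and the expected step from compound 1 is a 1.1-fold lower number from compound 1 to compound 3 (0.03 log units; within the scatter). Compound 3 is estimated at 1.2 mL/min in this assay, within a range of 0.7 mL/min to 2.2 mL/min.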

Compound 3, intrinsic clearance in a liver preparation (reported as CLH), per the amount of preparation that the assay uses: 1.23 mL/min
For compound 3 the middle estimate is 1.0-fold (0.01 log units) below the measured one; low and high end bracket the measured number.
By their numbers in this assay, from the lowest: compounds 2, 3 and 1 (each within the scatter of the next).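

On the sulfonyl side, going from 3,4-difluorophenyl to 3-chloro-4-fluorophenyl in this assay gives a 1.0-fold lower number from compound 1 to compound 3 (0.02 log units; within the scatter), so this aromatic carbon, ortho to a fluoro group and meta to a large group, accepts chloro in place of fluoro without a step beyond the scatter. Alongside a 1.1-fold lower number from compound 1 to compound 2 (0.05 log units; within the scatter) on the pendant phenyl, the same exchange has now been read at two different rings of compound 1, and at neither does it leave the scatter, so these steps do not separate the two places in this read-out. No measurement at hand gives a reason for this result.

Going by these compounds, both steps exchange one halogen for another, so it remains open whether a methyl, a methoxy group, a nitrile or an amine at this carbon would also stay within the scatter in this assay. Also open, on these data alone, are the effect of chloro on both the sulfonyl ring and the pendant phenyl in one compound, and that of removing the remaining fluoro group on the sulfonyl ring.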